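A few compounds are considered here, and "the series" means these few. Any claim that something is new, unique, unknown or untested is made for them only; others in the source may bear on it.

Measured compounds:
- compound 1 `Cn1ccc2c(Oc3ccc(NC(=O)c4cc5cccnc5n(-c5ccccc5)c4=O)cc3)ccnc21`: 5030 nM
- compound 2 `Cn1ccc2c(Oc3ccc(NC(=O)c4cc5cccnc5n(-c5ccc(Br)cc5F)c4=O)cc3)ccnc21`: "not determined" (no result reported)

In a functional assay on U-87MG ATCC cells for antiproliferative activity against U-87 MG (Homo sapiens), read by MTT assay, with a stated time of 72 h (on this read-out lower numbers stand for stronger inhibition and higher numbers for weaker inhibition), compound 1 gives 5030 nM. For compound 2 the same assay gives "not determined" (no result reported), so compound 2 stands without a number of its own. Compound 3 `Cn1ccc2c(Oc3ccc(NC(=O)c4cc5cccnc5n(-c5ccc(C(F)(F)F)cc5Cl)c4=O)cc3)ccnc21` differs from compound 2 by one exchange: 2-chloro-4-(trifluoromethyl)phenyl in place of 4-bromo-2-fluorophenyl on an aromatic nitrogen. For the measured compounds named here, with no measured step between compounds that differ in one place, the size and direction of this step cannot be read from the data, and a step within the usual scatter is as plausible as a larger one. Compound 3 is expected to give about 3000 nM, in a range from 500 nM to 15000 nM.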

Compound 3, half-maximal inhibitory concentration: 12600 nM
Estimate against measurement, compound 3: 4.2-fold (0.62 log units) below; measured number inside the range.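

In this assay, the group on the aromatic nitrogen can change the result: 2-chloro-4-(trifluoromethyl)phenyl in place of phenyl gives a 2.5-fold higher number from compound 1 to compound 3 (0.40 log units; beyond the scatter), so this substituted ring gives weaker inhibition than plain phenyl. For the compounds shown here, this is the first readable step at this position. Nothing at hand explains the change.

Steps involving compound 2 cannot be read, since it has no number of its own. On these data alone, it remains open whether the chlorine or the trifluoromethyl drives the step, and how an amine or a carboxylic acid on this ring would read.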